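Notes on the aromatic nitrogen substituent in this series

A few compounds are considered here, and "the series" means these few. Any claim that something is new, unique, unknown or untested is made for them only; others in the source may bear on it.

Measured compounds:
compound 1 `NC(=O)n1cc(C(=O)c2ccn3c2CSC3c2cccnc2)c2ccc(-c3ccc(F)cc3)cc21` gives 0.06 mg/kg in a functional assay on the whole organism for inhibition, with Rattus norvegicus as the target; on this read-out higher numbers stand for an effect only at larger amounts of compound and lower numbers for an effect already at smaller amounts
compound 2 `NCCn1cc(C(=O)c2ccn3c2CSC3c2cccnc2)c2ccc(-c3ccc(F)cc3)cc21` gives 1.3 mg/kg in this assay

Compound 2 stands highest of the two numbers; its nearest neighbour is compound 1. Within the data shown here, the single measured step, a 22-fold higher number from compound 1 to compound 2 (1.34 log units; beyond the scatter), is the only one that bears on the next change. Compound 3 `NNC(=O)n1cc(C(=O)c2ccn3c2CSC3c2cccnc2)c2ccc(-c3ccc(F)cc3)cc21` differs from compound 2 by aminocarbamoyl in place of 2-aminoethyl on an aromatic nitrogen. Aminocarbamoyl resembles the carbamoyl of compound 1 more than the 2-aminoethyl it replaces, so the expected step is a large reversal toward compound 1, an 11-fold lower number from compound 2 to compound 3 (1.03 log units; beyond the scatter). Compound 3 is estimated at 0.12 mg/kg, with a range from 0.03 mg/kg to 0.5 mg/kg.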

Compound 3, dose for half-maximal effect: 0.57 mg/kg
Beside the measured number, compound 3's estimate is 4.8-fold (0.68 log units) below it, outside the stated range (above it).
By their numbers in this assay, from the lowest: compound 1; then compound 3; then compound 2.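

In this assay, aminocarbamoyl on the aromatic nitrogen lowers the number only modestly relative to 2-aminoethyl (a 2.3-fold lower number from compound 2 to compound 3 (0.36 log units; beyond the scatter)) and does not reach carbamoyl (a 9.5-fold higher number from compound 1 to compound 3 (0.98 log units; beyond the scatter)). A carbonyl on this nitrogen therefore does not by itself give the number of compound 1: amino in place of hydrogen on the amide-type nitrogen also counts, with a step beyond the scatter. No evidence bears on why these steps have this size. Open, from the compounds shown here alone, is whether a methyl or hydroxyl in place of that amino keeps the low number of compound 1, and whether an acetyl on the aromatic nitrogen behaves like carbamoyl or aminocarbamoyl.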